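This account rests on a few compounds, and the source may have more. Where it says the series, first, only, none or still open, it means among the compounds named here.

Measured compounds in the series:
- compound 1, `O=c1[nH]cc(S(=O)(=O)Nc2ccccc2-c2cn(-c3cccc(Cl)c3)nn2)c(=O)[nH]1`: 2460 nM
- compound 2, `Cc1ccc(-n2cc(-c3ccc(NS(=O)(=O)c4c[nH]c(=O)[nH]c4=O)cc3)nn2)cc1`: 11600 nM

In a functional assay on HepG2 cells (Homo sapiens) for antiproliferative activity, read by MTT assay, with a stated time of 24 h (on this read-out higher numbers stand for weaker inhibition and lower numbers for stronger inhibition), compound 2 stands as the higher of the two numbers shown, with compound 1 below it by a margin beyond the usual scatter. Compound 3, `O=c1[nH]cc(S(=O)(=O)Nc2ccc(-c3cn(-c4ccc(Cl)cc4)nn3)cc2)c(=O)[nH]1`, differs from compound 2 by chloro in place of methyl on an aromatic carbon, a swap of one heavy atom for one heavy atom with no change in ring count, donors or acceptors. Going by the values given here, no measured pair isolates such a swap, so the step is expected to be small and within the scatter, a 1.4-fold lower number from compound 2 to compound 3 (0.14 log units; within the scatter), in no firm direction. Compound 3 is therefore estimated at 8500 nM, with a range of 3000 nM to 22000 nM.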

Compound 3, half-maximal inhibitory concentration: 1980 nM
Estimate against measurement, compound 3: 4.3-fold (0.63 log units) above; the whole stated range lies above it.
By their numbers in this assay, from the lowest: compounds 3 and 1 (each within the scatter of the next); then compound 2.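

In this assay, the position para to a large group on the six-membered aromatic ring of carbon only proves sensitive to a swap of one heavy atom: chloro in place of methyl gives (a 5.9-fold lower number from compound 2 to compound 3 (0.77 log units; beyond the scatter)). The change from 4-methylphenyl to 4-chlorophenyl therefore moves the number beyond the scatter, with no change in ring count or in hydrogen-bond donors or acceptors. Nothing available accounts for this step. From the compounds shown here alone, whether a fluoro, a methoxy, an amine or a carboxylic acid at this position would give a lower or higher number remains open.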